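Adding a hydroxy to the pyrrolidine of compound 3

The compounds below may be only part of what the source reports. "The series", "measured", "known", "first", "only" and "open" are said of these compounds alone.

Compound 3 `COc1cc[nH]c1/C=C1\C(=O)Nc2ccc(F)c(C#C[C@@H]3CCCN3)c21` gives 31 nM in a functional assay on MDA-MB-435 cells (Homo sapiens) for inhibition (on this read-out lower numbers stand for stronger inhibition and higher numbers for weaker inhibition), the lowest of the two numbers recorded; compound 2 `COc1cc[nH]c1/C=C1\C(=O)Nc2ccc(F)c(C#C[C@@H](N)[C@@H](C)O)c21` gives 300 nM in this assay, and a 9.7-fold lower number from compound 2 to compound 3 (0.99 log units; beyond the scatter). Compound 1 `COc1cc[nH]c1/C=C1\C(=O)Nc2ccc(F)c(I)c21` sits at a limit of this assay, > 30000 nM, which is a limit and not a number (the limit of > 30000 nM in this assay, at which 1 of the 3 values shown sits). From that limit, an at least 100-fold lower number from compound 1 to compound 2 (2.00 log units; beyond the scatter) and an at least 960-fold lower number from compound 1 to compound 3 (2.98 log units; beyond the scatter). Compound 4 `COc1cc[nH]c1/C=C1\C(=O)Nc2ccc(F)c(C#C[C@@H]3C[C@@H](O)CN3)c21` differs from compound 3 by hydroxy in place of hydrogen on a saturated ring carbon. For the measured compounds named here, none of the measured steps alters a ring carbon of the pyrrolidine; the only step touching the group on the triple bond, a 9.7-fold lower number from compound 2 to compound 3 (0.99 log units; beyond the scatter), exchanges that whole group, so a step no larger than the scatter is expected, a 1.3-fold higher number from compound 3 to compound 4 (0.11 log units; within the scatter). Compound 4 is therefore estimated at 40 nM, within 12 nM to 130 nM.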

Compound 4, half-maximal inhibitory concentration: 63 nM
Beside the measured number, compound 4's estimate is 1.6-fold (0.20 log units) below it, and the stated range covers the measured number.
By their numbers in this assay, from the lowest: compound 3; then compound 4; then compound 2. At a limit, above all of these: compound 1.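

For the compounds shown here, the first change on a ring carbon of the pyrrolidine, two ring bonds from the ring nitrogen, gives a 2.0-fold higher number from compound 3 to compound 4 (0.31 log units; beyond the scatter) in this assay, so this position takes a hydroxy at a modest cost. The 4-hydroxypyrrolidin-2-yl group still compares well with 1-amino-2-hydroxypropyl, with a 4.8-fold lower number from compound 2 to compound 4 (0.68 log units; beyond the scatter). Compound 1 stands at a limit and not a number, and from that limit the step is an at least 470-fold lower number from compound 1 to compound 4 (2.67 log units; beyond the scatter).

As far as these compounds go, whether a methoxy or an amine on this ring carbon would behave like the hydroxy remains open. So does the effect of the hydroxy in its opposite configuration.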